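Removing the Cyclohexyl Group and Cell Tolerance

A few compounds are considered here, and "the series" means these few. Any claim that something is new, unique, unknown or untested is made for them only; others in the source may bear on it.

Of the compounds shown here, three have been measured in an ADME assay on MDBK cells (Bos taurus) for cytotoxicity, read by MTT assay, with a stated time of 96 h; a higher number here means that more compound is tolerated, a lower number that less compound is tolerated.

Compound 1 `O=[N+]([O-])c1ccc(-c2nc3cc(C(F)(F)F)ccc3[nH]2)cc1` gives 6000 nM.
Compound 2 `CC(=O)Nc1ccc(-c2nc3cc([N+](=O)[O-])ccc3[nH]2)cc1` gives > 100000 nM.
Compound 3 `CC(=O)Nc1ccc(-c2nc3cc(C(F)(F)F)ccc3n2C2CCCCC2)cc1` gives 17000 nM.

Of the two numbers, compound 3 has the higher one, so more of it is tolerated; compound 1 sits lower, and this gap lies beyond the usual scatter. For compound 2 the value of > 100000 nM is a limit of this assay and not a number. Within the data shown here, no pair among the measured compounds differs in only one place, so no single structural step can be read off from them.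

Compound 4 `CC(=O)Nc1ccc(-c2nc3cc(C(F)(F)F)ccc3[nH]2)cc1` is the next compound. It differs from compound 3 by hydrogen in place of cyclohexyl on an aromatic nitrogen.

Among the measured compounds shown here, with no matching step among the measured compounds, the expectation rests on the change alone. A rise in this assay, of modest size and only slightly beyond the scatter, is expected from compound 3 to compound 4, that is a 1.8-fold higher number from compound 3 to compound 4 (0.25 log units; within the scatter). Compound 4 is expected to give about 30000 nM, with a likely range from 8000 nM to 100000 nM.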

Compound 4, half-maximal cytotoxic concentration: 50000 nM
Compound 4: middle estimate off by 1.7-fold (0.22 log units), on the low side; measured number inside the range.
By their numbers in this assay, from the lowest: compound 1; then compound 3; then compound 4. At a limit, above all of these: compound 2.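

In this assay, among these compounds, hydrogen in place of cyclohexyl on an aromatic nitrogen gives a 2.9-fold higher number from compound 3 to compound 4 (0.47 log units; beyond the scatter), the first direct reading of this position, and here the unsubstituted nitrogen is better tolerated. With that nitrogen left free, acetamido in place of nitro on an aromatic carbon gives an 8.3-fold higher number from compound 1 to compound 4 (0.92 log units; beyond the scatter), so a change elsewhere on the core also shifts cell tolerance beyond the scatter. Trifluoromethyl in place of nitro on an aromatic carbon gives an at least 2.0-fold lower number from compound 2 to compound 4 (0.30 log units; that floor lies within the scatter), but this step is only a floor, set by the limit of compound 2: the limit of > 100000 nM in this assay, at which 1 of the 4 values shown sits.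

From the compounds shown here alone, how a methyl group, a longer chain or an amine-bearing chain on this nitrogen would compare with hydrogen and cyclohexyl remains open. Going by these compounds, whether the step from cyclohexyl to hydrogen keeps its size with other groups on the core also remains open, as it rests on a single pair.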